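Two Hydroxyls Replace Three Methoxys on the Hydrazone Aryl Ring

The source may report more compounds than this note shows. Statements on the series, on what has been measured and on what is new or still open speak of the compounds shown alone.

Compound 1 `CN(C)CCn1cnnc1-c1cc(Oc2ccc(NC(=O)N/N=C/c3ccccc3O[N+](=O)[O-])cc2F)ccn1` gives 1270 nM in a functional assay on NCI-H460 cells (Homo sapiens) for cytotoxicity, read by MTT assay, with a stated time of 72 h; a higher number here means a weaker inhibitor, a lower number a stronger inhibitor.
Compound 2 `COc1cc(/C=N/NC(=O)Nc2ccc(Oc3ccnc(-c4nncn4CCN(C)C)c3)c(F)c2)ccc1O` gives 57 nM in this assay.
Compound 3 `COc1cc(/C=N/NC(=O)Nc2ccc(Oc3ccnc(-c4nncn4CCN(C)C)c3)c(F)c2)cc(OC)c1OC` gives 2770 nM in this assay.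

Compound 3 stands highest of the three: a 2.2-fold higher number from compound 1 to compound 3 (0.34 log units; beyond the scatter) and a 49-fold higher number from compound 2 to compound 3 (1.69 log units; beyond the scatter). Compound 4 `CN(C)CCn1cnnc1-c1cc(Oc2ccc(NC(=O)N/N=C/c3ccc(O)cc3O)cc2F)ccn1` differs from it by 2,4-dihydroxyphenyl in place of 3,4,5-trimethoxyphenyl on a carbon with a double bond to nitrogen. Of the measured steps, a 49-fold higher number from compound 2 to compound 3 (1.69 log units; beyond the scatter) bears most directly, since the ring carrying a hydroxyl and one methoxy sits far below the trimethoxyphenyl ring; a 22-fold lower number from compound 1 to compound 2 (1.35 log units; beyond the scatter) points the same way. Going by the values given here, a large fall in this assay is therefore expected, a 9.2-fold lower number from compound 3 to compound 4 (0.97 log units; beyond the scatter), although a ring with two hydroxyls and no methoxy has no measured precedent here, which widens the range. Compound 4 is estimated at 300 nM, within 60 nM to 1500 nM.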

Compound 4, half-maximal inhibitory concentration: 11300 nM
Compound 4: the middle estimate sits 38-fold (1.58 log units) below what was measured; the whole stated range lies below it.
By their numbers in this assay, from the lowest: compound 2; then compound 1; then compound 3; then compound 4.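

The 2,4-dihydroxyphenyl group is the weakest of the four groups compared on a carbon with a double bond to nitrogen: a 4.1-fold higher number from compound 3 to compound 4 (0.61 log units; beyond the scatter) and an 8.9-fold higher number from compound 1 to compound 4 (0.95 log units; beyond the scatter) and a 200-fold higher number from compound 2 to compound 4 (2.30 log units; beyond the scatter) all end with it in this assay here. A hydroxyl on this ring therefore does not bring strength by itself, since the hydroxyl-bearing rings of compound 2 and compound 4 stand at opposite ends of the series.

Which hydroxyl of compound 4 goes with the loss stays open. So does where a ring carrying an amine or a carboxylic acid would fall. No measurement shown here accounts for the gap.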